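A Nitro Swap in a Series Sitting at the Limit

A few compounds are considered here, and "the series" means these few. Any claim that something is new, unique, unknown or untested is made for them only; others in the source may bear on it.

compound 1 `COC(=O)[C@H](CCSC)NC(=O)c1ccc(NCc2cncn2Cc2ccc(C#N)cc2)cc1-c1ccccc1` — > 10 uM
compound 2 `COC(=O)[C@H](CCSC)NC(=O)c1ccc(NCc2cncn2Cc2ccc(Cl)cc2)cc1-c1ccccc1` — > 10 uM
compound 3 `CSCC[C@H](NC(=O)c1ccc(NCc2cncn2Cc2ccc(Cl)cc2)cc1-c1ccccc1)C(=O)O` — > 10 uM

Of the compounds shown here, three sharing one core have been measured in a functional assay on NIH3T3 cells (Mus musculus); a lower number here means that less compound is needed, a higher number that more compound is needed for the effect. In this assay compound 1 gives > 10 uM, which is a limit of the assay and not a number. Compound 2 likewise reaches only the limit > 10 uM. Compound 3 also stops at the limit > 10 uM. Compound 2 therefore stands where the other two stand: at a limit, with no number of its own. The two single-point changes among these compounds, a step that the two limits leave unreadable from compound 1 to compound 2 and a step that the two limits leave unreadable from compound 2 to compound 3, are both unreadable because of the limit of > 10 uM in this assay, at which 3 of the 3 values shown sit.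

Compound 4 `COC(=O)[C@H](CCSC)NC(=O)c1ccc(NCc2cncn2Cc2cccc([N+](=O)[O-])c2)cc1-c1ccccc1` differs from compound 2 by 3-nitrophenyl in place of 4-chlorophenyl on a saturated chain carbon bound to an aromatic nitrogen. Among the compounds with values here, no measured step bears readably on this change; the only evidence is that every value so far sits at the limit. In this assay the step from compound 2 to compound 4 is thus expected to be small, a step that the limit leaves unreadable from compound 2 to compound 4, because the limit of > 10 uM in this assay, at which 3 of the 3 values shown sit, offers no reason to expect otherwise. Compound 4 is expected to give 15 uM in this assay, within 5 uM to 50 uM, and most probably again only a limit.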

Compound 4, concentration for half-maximal effect: > 10 uM
Compound 4 ended at the assay's limit; the forecaster's own chance of this, stated with the estimate: 80%; the middle value is on the limit's open side.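

In this assay compound 4 gives > 10 uM, a limit of the assay and not a number. Neither the step from compound 2 to compound 4 nor the step from compound 1 to compound 4 can be read: the limit of > 10 uM in this assay, at which 4 of the 4 values shown sit.

The compounds shown leave open whether any change to the shared core gives a measurable value in this assay.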